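The source may hold more compounds than are shown below. What is called first, only, known or untested is meant among the compounds shown, and "the series" means these compounds.

Series values in an ADME assay on L1210 cells (Mus musculus) for cytotoxicity, with a stated time of 48 h; on this read-out lower numbers stand for stronger inhibition and higher numbers for weaker inhibition:
- Compound 1 `C=C1[C@H](C)CCC[C@]1(C)CC/C(C)=C/CC1=C(O)C(=O)C=C(N[C@@H](C(=O)O)C(C)C)C1=O`: 3.4 ug/mL
- Compound 2 `CC1=CCC[C@](C)(CC/C(C)=C/CC2=C(O)C(=O)C=C(N[C@@H](C(=O)O)[C@@H](C)O)C2=O)[C@@H]1C`: > 10 ug/mL
- Compound 3 `C=C1[C@H](C)CCC[C@]1(C)CC/C(C)=C/CC1=C(O)C(=O)C=C(N[C@@H](C(=O)O)[C@H](C)O)C1=O`: 4.6 ug/mL

Not yet measured: compound 4 `CC1=CCC[C@](C)(CC/C(C)=C/CC2=C(O)C(=O)C=C(N[C@@H](C(=O)O)C(C)C)C2=O)[C@@H]1C`.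

Compound 2 gives > 10 ug/mL, which is a limit of the assay and not a number. Its exact place in the series is therefore unknown, and any step starting from it is only loosely defined.

The change from compound 2 to compound 4 is isopropyl in place of 1-hydroxyethyl on a saturated chain carbon bound to an amine nitrogen and a carbonyl carbon.

Within the data shown here, one measured step bears on this exchange. It runs in the reverse sense, on the core shared by compound 1 and compound 3, which is not the core of compound 2 and compound 4: a 1.4-fold higher number from compound 1 to compound 3 (0.13 log units; within the scatter). On that evidence, no change beyond the scatter is expected in this assay, and no direction can be assigned. Compound 4 is thus expected to lie near the limit of compound 2. Some allowance is expected towards compound 1 at 3.4 ug/mL.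

The expected step is an at least 1.4-fold lower number from compound 2 to compound 4 (0.15 log units; that floor lies within the scatter), a rough estimate from a limit. For compound 4 the estimate is 7 ug/mL, with an expected range of 3 ug/mL to 16 ug/mL.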

Compound 4, half-maximal inhibitory concentration: 3 ug/mL
Beside the measured number, compound 4's estimate is 2.3-fold (0.37 log units) above it; the measured number falls inside the stated range.
By their numbers in this assay, from the lowest: compounds 4, 1 and 3 (each within the scatter of the next). At a limit, above all of these: compound 2.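

On the core of compound 4, in this assay, isopropyl in place of 1-hydroxyethyl gives an at least 3.3-fold lower number from compound 2 to compound 4 (0.52 log units; beyond the scatter), whereas the reverse exchange on the core of compound 1 gives a 1.4-fold higher number from compound 1 to compound 3 (0.13 log units; within the scatter). Compound 2 gives > 10 ug/mL, which is a limit of the assay and not a number, so the size of the first step is only a floor. With isopropyl held in place, the change of core gives a 1.1-fold lower number from compound 1 to compound 4 (0.05 log units; within the scatter), so the two cores are not told apart while isopropyl is present, and the exchange at this position reaches beyond the scatter only on the core of compound 4.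

The 1-hydroxyethyl stereocentre is drawn in the opposite sense in compound 2 and compound 3, so the compounds shown do not separate the core from that stereocentre as the source of the different outcomes. They also leave open how this position responds to a hydroxymethyl group, an aminoalkyl chain or a longer alkyl chain in place of isopropyl.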